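The source may report more compounds than this note shows. Statements on the series, on what has been measured and on what is new or still open speak of the compounds shown alone.

Measured compounds:
compound 1 `O=C(c1ccc(OCCCN2CC[C@H](NS(=O)(=O)c3cccc(F)c3)C2)cc1)C1CC1`; in an assay on isolated protein for binding affinity to histamine H2 receptor (Homo sapiens) (a higher number here means a weaker inhibitor, a lower number a stronger inhibitor), compound 1 gives 1600 nM.
compound 2 `N#Cc1ccc(S(=O)(=O)N[C@H]2CCN(CCCOc3ccc(C(=O)C4CC4)cc3)C2)cc1`; in this assay compound 2 gives 1600 nM.
compound 3 `O=C(c1ccc(OCCCN2CC[C@H](NS(=O)(=O)c3ccccc3F)C2)cc1)C1CC1`; in this assay compound 3 gives 1550 nM.

All three share the same core and differ only in the aryl group on the sulfonyl sulfur. Their three values lie within the scatter of one another, so compound 3 sits level with compound 1 and compound 2: a 1.0-fold lower number from compound 1 to compound 3 (0.01 log units; within the scatter) and a 1.0-fold lower number from compound 2 to compound 3 (0.01 log units; within the scatter) show no separation, and no change at the digits printed from compound 1 to compound 2 (within the scatter) is equally flat.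

Compound 4 `CCc1ccc(S(=O)(=O)N[C@H]2CCN(CCCOc3ccc(C(=O)C4CC4)cc3)C2)cc1` carries the next such exchange: 4-ethylphenyl in place of 2-fluorophenyl on a sulfonyl sulfur. The three measured steps bear directly on it, each swapping one aryl group on the sulfonyl sulfur for another, and none of them moved beyond the scatter. For the measured compounds named here, no measured step covers a 4-ethylphenyl, so the expectation rests on the flat behaviour of the aryl variations measured so far. In this assay the step from compound 3 to compound 4 is expected to be a 1.0-fold lower number from compound 3 to compound 4 (0.01 log units; within the scatter), that is, nothing beyond the scatter. For compound 4 the estimate in this assay is 1500 nM, with a range from 700 nM to 3500 nM.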

Compound 4, inhibition constant: 330 nM
Compound 4: middle estimate off by 4.5-fold (0.66 log units), on the high side; measured number outside the range, below it.
By their numbers in this assay, from the lowest: compound 4; then compounds 3, 1 and 2 (each within the scatter of the next).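

In this assay the aryl group on the sulfonyl sulfur can move the number after all: the exchange for 4-ethylphenyl gives a 4.7-fold lower number from compound 3 to compound 4 (0.67 log units; beyond the scatter) and a 4.8-fold lower number from compound 1 to compound 4 (0.69 log units; beyond the scatter) and, with ethyl in place of cyano on an aromatic carbon, a 4.8-fold lower number from compound 2 to compound 4 (0.69 log units; beyond the scatter) in the direction of a stronger inhibitor. For the compounds shown here, these are the first steps beyond the scatter, whereas 2-fluorophenyl, 3-fluorophenyl and 4-cyanophenyl remain level with one another, so the separation rests on compound 4 alone. Nothing available accounts for this step.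

The compounds shown do not tell whether the step belongs to ethyl specifically or extends to methyl, propyl or a longer chain on the same aromatic carbon. Nor do they tell how 2-ethylphenyl or 3-ethylphenyl would compare with 4-ethylphenyl.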